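This account rests on a few compounds, and the source may have more. Where it says the series, first, only, none or still open, it means among the compounds named here.

In a functional assay on T98G cells (Homo sapiens) for inhibition, read by colorimetric assay and MTT assay, with a stated time of 72 h (on this read-out higher numbers stand for weaker inhibition and lower numbers for stronger inhibition), compound 3 `CCCCOc1ncc(-c2ccccc2OC)n1C` gives 96000 nM, and compound 1 `Cn1c2cnc1OCCCCCCCCCOc1ccccc1-2` gives 74000 nM. These two values lie within the usual scatter of each other. Compound 2 `C=CCCCCOc1ccccc1-c1cnc(OCCCC=C)n1C` gives a clearly lower number, 3000 nM, so compound 3 shares the weak end of this small set with compound 1.

The next compound to consider is compound 4 `COc1ccccc1-c1cnc(OC)n1C`, a smaller relative of compound 3. The change is confined to one place: hydrogen in place of propyl on a saturated chain carbon bound to an oxygen on an aromatic ring. In words, hydrogen stands in place of propyl on a saturated chain carbon bound to an oxygen on an aromatic ring, which turns butoxy into methoxy.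

Going by the values given here, no two measured compounds here differ in only one place, so the data offer no direct guide to the size of this step. Compound 3, at 96000 nM, already needs a very high concentration to reach half-maximal inhibition, and nothing measured suggests that shortening this chain would bring a large gain. The expectation is therefore a small move towards a higher number, quite possibly none beyond the scatter. The expected step is a 1.4-fold higher number from compound 3 to compound 4 (0.13 log units; within the scatter). For compound 4 the estimated value is 130000 nM, with an expected range from 50000 nM to 300000 nM.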

Compound 4, half-maximal inhibitory concentration: > 100000 nM
Compound 4 ended at the assay's limit; the forecaster's own chance of this, stated with the estimate: 15%; the middle value is on the limit's open side.
By their numbers in this assay, from the lowest: compound 2; then compounds 1 and 3 (each within the scatter of the next). At a limit, above all of these: compound 4.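

In this assay compound 4 gives > 100000 nM, which is a limit of the assay and not a number. Going by these compounds alone, this is the first change in the set confined to one place: hydrogen in place of propyl on a saturated chain carbon bound to an oxygen on an aromatic ring, turning butoxy into methoxy, gives an at least 1.0-fold higher number from compound 3 to compound 4 (0.01 log units; that floor lies within the scatter). The change therefore brings no lower number, but its true size cannot be read, and the step may be anything from within the scatter to far larger, because the result sits at the end of the measurable range: the limit of > 100000 nM in this assay, at which 1 of the 4 values shown sits.

Still open, from the compounds shown here alone, is whether any other group at this place would give a clearly lower number, for instance a longer saturated chain such as octyl, or an amine or a carboxylic acid in place of propyl. Compound 2 gives a much lower number than compound 3, but the two differ in more than one place, so that gap cannot be credited to this position alone, and what the chain contributes on its own remains unsettled.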